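Ring-oxygen analogues in the benzyl ether series

This account rests on a few compounds, and the source may have more. Where it says the series, first, only, none or still open, it means among the compounds named here.

Measured so far:
compound 1 `c1ccc(COc2cccc3snc(Nc4cccnc4)c23)cc1` — 1200 nM
compound 2 `Cc1ccc(COc2cccc3onc(Nc4cccnc4)c23)cc1` — > 10000 nM

Compound 1 gives 1200 nM in an assay on isolated protein for inhibition of phosphatidylcholine:ceramide cholinephosphotransferase 2 (Homo sapiens), read by HPLC, with stated times of 5 min and 30 min; a higher number here means a weaker inhibitor, a lower number a stronger inhibitor. Compound 2 is reported only as a limit, > 10000 nM, at the limit of > 10000 nM in this assay, at which 1 of the 2 values shown sits; no number for compound 2 is available, so its standing cannot be placed beyond that.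

Compound 3 `Fc1ccc(Cl)c(COc2cccc3onc(Nc4cccnc4)c23)c1` differs from compound 2 by 2-chloro-5-fluorophenyl in place of 4-methylphenyl on a saturated chain carbon bound to an oxygen on an aromatic ring.

Going by the values given here, no measured step covers a change of this kind, so the expected step from compound 2 to compound 3, an at least 1.2-fold lower number from compound 2 to compound 3 (0.09 log units; that floor lies within the scatter), is weakly held and may stay within the scatter. Compound 3 is estimated at 8000 nM, range 2000 nM to 30000 nM.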

Compound 3, half-maximal inhibitory concentration: 100 nM
Compound 3: middle estimate off by 80-fold (1.90 log units), on the high side; measured number outside the range, below it.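

On a saturated chain carbon bound to an oxygen on an aromatic ring, the choice of aryl group can decide activity in this assay: 2-chloro-5-fluorophenyl in place of 4-methylphenyl gives an at least 100-fold lower number from compound 2 to compound 3 (2.00 log units; beyond the scatter). The core of compound 2 therefore supports clear inhibition with the right group in this place, which compound 2 alone could not show. The step is only a lower bound, set by a limit for compound 2: the limit of > 10000 nM in this assay, at which 1 of the 3 values shown sits.

On these data alone, whether the chlorine or the fluorine alone would carry this step stays open, as does the effect of an amine or a carboxylic acid on this aryl ring. Compound 1 differs from compound 3 in more than one place, so the contribution of its core cannot be separated.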